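This account rests on a few compounds, and the source may have more. Where it says the series, first, only, none or still open, it means among the compounds named here.

Three related compounds have been tested in a functional assay on HepG2 cells (Homo sapiens) for inhibition, read by MTT assay, with a stated time of 72 h, tested at 50 uM; on this read-out higher numbers stand for more inhibition of growth at the one concentration tested and lower numbers for less inhibition of growth. Compound 1 `C=CCc1ccc(OCc2cn(-c3ccccc3CO)nn2)c(O)c1` gives 8.5%. Compound 2 `C=CCc1ccc(OCc2cn(-c3cc(OC)c(OC)c(OC)c3)nn2)c(O)c1` gives 2.5%, and compound 3 `C#CCOc1ccc(CC=C)cc1O` gives 5.6%. Of the three, compound 1 shows the top number, yet its gaps to compound 3 and to compound 2 both fall within the usual scatter, so the three cannot be told apart on this read-out. Compound 4 `C=CCc1ccc(OCc2cn(-c3ccc(OC)cc3)nn2)c(O)c1` has not yet been measured. It differs from compound 1 in one place: 4-methoxyphenyl in place of 2-(hydroxymethyl)phenyl on an aromatic nitrogen. For the measured compounds named here, no step between two measured compounds of this kind is available, so the expectation rests on the three numbers alone, which all sit low and close together. The step of a number 2.5 percentage points lower from compound 1 to compound 4 (within the scatter) is expected to be none beyond the scatter. Compound 4 is therefore estimated at 6%, within a range from 0% to 15%.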

Compound 4, percent growth inhibition at one concentration: 49.9%
The estimate for compound 4 lay 43.9 percentage points below the measured number, outside the stated range (above it).
By their numbers in this assay, from the lowest: compounds 2, 3 and 1 (each within the scatter of the next); then compound 4.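

In this assay, the group on this aromatic nitrogen proves to matter a great deal: 4-methoxyphenyl in place of 2-(hydroxymethyl)phenyl gives a number 41.4 percentage points higher from compound 1 to compound 4 (beyond the scatter), even though the two compounds have the same atoms, joined differently. The three earlier numbers, all low and close together, gave no hint of such sensitivity. Nothing at hand points to a cause of this step. As far as these compounds go, it remains open whether the gain comes from the methoxy group itself or from losing 2-(hydroxymethyl)phenyl. From the compounds shown here alone, how 4-ethoxyphenyl or 4-aminophenyl would behave at this position is also open.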